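The source may report more compounds than this note shows. Statements on the series, on what has been measured and on what is new or still open speak of the compounds shown alone.

Of the compounds shown here, three have been measured. In an in vitro functional assay on 1321-N1 cells for agonist activity at P2Y purinoceptor 6 (Homo sapiens) (a lower number here means that less compound is needed, a higher number that more compound is needed for the effect), compound 1 `O=C(O)CSc1ccn([C@@H]2O[C@H](COP(=O)(O)OP(=O)(O)O)[C@@H](O)[C@H]2O)c(=O)n1` gives 1700 nM, which is the second highest of the three numbers. Its nearest neighbour is compound 2 `O=c1ccn([C@@H]2O[C@@]3(COP(=O)(O)OP(=O)(O)O)C[C@H]3[C@H]2O)c(=O)[nH]1`, which in this assay gives 3500 nM, a higher number that lies beyond the scatter. The furthest is compound 3 `O=c1ccn([C@]23CC2[C@H](COP(=O)(O)OP(=O)(O)O)[C@@H](O)C3)c(=O)[nH]1`, which in this assay gives 230 nM, a lower number, also beyond the scatter. Compound 4 `C=CCSc1ccn([C@@H]2O[C@H](COP(=O)(O)OP(=O)(O)O)[C@@H](O)[C@H]2O)c(=O)n1` differs from compound 1 by vinyl in place of carboxy on a saturated chain carbon bound to a sulfur. No comparable step has been measured among these compounds, so nothing is known about the effect of this change. Compound 4 is therefore expected to show a small step of a 1.5-fold higher number from compound 1 to compound 4 (0.17 log units; within the scatter) that may not exceed the scatter, with an estimated value of 2500 nM in the range 600 nM to 10000 nM.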

Compound 4, half-maximal effective concentration: 560 nM
For compound 4 the middle estimate is 4.5-fold (0.65 log units) above the measured one; measured number below the stated range.
By their numbers in this assay, from the lowest: compound 3; then compound 4; then compound 1; then compound 2.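

In this assay, among these compounds, exchanging (carboxymethyl)sulfanyl for allylsulfanyl gives a 3.0-fold lower number from compound 1 to compound 4 (0.48 log units; beyond the scatter) and is the first single change that can be read. At this position, the carboxy group is therefore not needed for agonist activity, and the entering vinyl, which has no hydrogen-bond donor or acceptor, goes with a modestly lower number. Nothing available accounts for this step. Going by these compounds, whether a saturated propyl chain, a longer chain or an amine at this place would lower the number further remains open.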